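Sulfonyl group exchange in a series at its limit

The source may hold more compounds than are shown below. What is called first, only, known or untested is meant among the compounds shown, and "the series" means these compounds.

The compounds share one core and differ in the group on the sulfonyl sulfur. In an ADME assay on HCT-116 cells (Homo sapiens) for cytotoxicity, read by CellTiter-Glo, with a stated time of 72 h (on this read-out lower numbers stand for stronger inhibition and higher numbers for weaker inhibition), compound 1 (`Cc1noc(C)c1S(=O)(=O)N1CCC(N2CCC(C)CC2)CC1`) gives > 10000 nM, which is a limit. Compound 2 (`CC1CCN(C2CCN(S(=O)(=O)c3cccc(N)c3)CC2)CC1`) gives > 5000 nM, also a limit. Compound 3 (`Cc1cccc(S(=O)(=O)N2CCC(N3CCC(C)CC3)CC2)c1`) gives > 5000 nM, again a limit, so compound 3 has no number of its own, and the other two values shown are no numbers either.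

Compound 4 (`CC1CCN(C2CCN(S(=O)(=O)c3nccn3C)CC2)CC1`) comes next, with 1-methyl-1H-imidazol-2-yl in place of 3-methylphenyl on a sulfonyl sulfur.

Among the compounds with values here, three measured steps bear on this change. Two exchange the group on the sulfonyl sulfur: a step that the two limits leave unreadable from compound 1 to compound 3 and a step that the two limits leave unreadable from compound 1 to compound 2. The third, a step that the two limits leave unreadable from compound 2 to compound 3, puts methyl in place of amino on an aromatic carbon. None of the three has a readable size, and none gives a direction. Every group tried on the sulfonyl sulfur so far ends at a limit, and that holds for all three compounds without exception.

No step beyond the scatter is therefore expected in this assay, and the estimated change is a step that the limit leaves unreadable from compound 3 to compound 4. Compound 4 is estimated at 10000 nM, within an expected range of 5000 nM to 30000 nM, and is expected to be reported most likely as a limit.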

Compound 4, half-maximal inhibitory concentration: > 10000 nM
Compound 4: no number, only a limit; the forecaster's own chance of this, stated with the estimate: 90%; the middle value sits exactly at the limit.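

In this assay, within the data shown here, compound 4 ends at a limit, as do compound 1, compound 2 and compound 3, so no step between compound 4 and any of these three can be read. The compounds shown leave open whether any group on the sulfonyl sulfur gives a measurable value on this read-out.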